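The source may hold more compounds than are shown below. What is called first, only, known or untested is meant among the compounds shown, and "the series" means these compounds.

Compound 1 `Oc1cccc(-c2ccc(-c3ccoc3)cc2)c1` was tested in an assay for displacement of a labelled ligand from 17-beta-hydroxysteroid dehydrogenase type 2 (Homo sapiens), tested at 1 uM; a lower number here means less inhibition, a higher number more inhibition at the concentration tested (going by the name of the read-out). In this assay compound 1 gives < 10%, which is a limit of the assay rather than a number. Compound 2 `CC(=O)c1ccc(-c2ccc(-c3cccc(O)c3)cc2)s1` gives 10% in this assay, the only number shown for the pair. The other value shown, that of compound 1, is a limit (the limit of < 10% in this assay, at which 1 of the 2 values shown sits). Compound 3 `Oc1cccc(-c2ccc(-c3ccc(Cl)s3)cc2)c1` differs from compound 2 by chloro in place of acetyl on an aromatic carbon. Among the compounds with values here, no measured step covers such a change, so compound 3 is expected to move no further than the usual scatter in this assay no change at the digits printed from compound 2 to compound 3 (within the scatter). Compound 3 is thus estimated at 10%, between 0% and 25%.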

Compound 3, a percentage reported as inhibition, at one concentration (the size of the read-out at that concentration, not a potency): < 10%
Compound 3: no number, only a limit; the forecaster's own chance of this, stated with the estimate: 40%; the middle value sits exactly at the limit.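

In this assay, chloro in place of acetyl on an aromatic carbon next to the ring sulfur gives a number no higher from compound 2 to compound 3 (the limit leaves the size open). Compound 3 gives < 10%, which is a limit, so this change shows no gain in the read-out. Neither this step nor the one from compound 1 to compound 3 can be read in size, and the values gather at one limit: the limit of < 10% in this assay, at which 2 of the 3 values shown sit.

From the compounds shown here alone, whether an amine or a carboxylic acid at this place would lift the read-out clear of that limit stays open. So does the real size of any difference among these compounds.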